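The source may hold more compounds than are shown below. What is called first, only, known or untested is meant among the compounds shown, and "the series" means these compounds.

Measured compounds:
- Compound 1, `N#Cc1cnc(NCc2ccccc2C(F)(F)F)cc1N[C@H]1CC[C@H](O)CC1`, gives 4000 nM in an assay on isolated protein for inhibition of protein kinase C theta type (Homo sapiens), read by TR-FRET, with a stated time of 2 h; a higher number here means a weaker inhibitor, a lower number a stronger inhibitor.
- Compound 2, `N#Cc1cnc(NCc2ccccc2C(F)(F)F)cc1N[C@H]1C[C@H](C(N)=O)C1`, gives 5000 nM in this assay.

Within the data shown here, compound 2 holds the higher of the two numbers so far, but its nearest neighbour is compound 1, and the step of a 1.3-fold higher number from compound 1 to compound 2 (0.10 log units; within the scatter) is one the scatter alone could produce. Compound 3, `N#Cc1cnc(NCc2ccccc2C(F)(F)F)cc1N[C@H]1CC[C@@H](C(N)=O)CC1`, differs from compound 2 by 4-carbamoylcyclohexyl in place of 3-carbamoylcyclobutyl on a nitrogen on an aromatic ring. Among the measured compounds shown here, the only step that bears on this change, a 1.3-fold higher number from compound 1 to compound 2 (0.10 log units; within the scatter), swapped one saturated ring for another and barely moved the number. A return to a six-membered ring is therefore expected to give little beyond the scatter, with the step of a 1.3-fold lower number from compound 2 to compound 3 (0.10 log units; within the scatter). Compound 3 is estimated at 4000 nM, in the range 1500 nM to 11000 nM.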

Compound 3, half-maximal inhibitory concentration: 20 nM
Compound 3: middle estimate off by 200-fold (2.30 log units), on the high side; the measured number lies below the stated range.
By their numbers in this assay, from the lowest: compound 3; then compounds 1 and 2 (each within the scatter of the next).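

At this nitrogen, the carbamoyl group and the six-membered ring work only as a pair: the carbamoyl group on a cyclobutyl ring stays weak, whereas 4-carbamoylcyclohexyl gives a large gain (a 250-fold lower number from compound 2 to compound 3 (2.40 log units; beyond the scatter)). A six-membered ring alone is not enough either, since replacing 4-hydroxycyclohexyl with 4-carbamoylcyclohexyl yields a similar gain (a 200-fold lower number from compound 1 to compound 3 (2.30 log units; beyond the scatter)). Nothing measured here explains this gain.

As far as these compounds go, it remains open whether a carboxylic acid or an amine at the same place on the cyclohexyl ring would keep the gain. From the compounds shown here alone, the other stereoisomer of 4-carbamoylcyclohexyl also remains open.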